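A few compounds are considered here, and "the series" means these few. Any claim that something is new, unique, unknown or untested is made for them only; others in the source may bear on it.

Three compounds sharing one core have been examined in a functional assay on HCT-15 cells (Homo sapiens) for inhibition; a lower number here means a stronger inhibitor, a higher number a weaker inhibitor. Compound 1 `Oc1ccc(-c2cc(-c3ccccc3F)cc(-c3ccc(O)cc3)n2)cc1` gives 8180 nM. Compound 2 `Oc1ccc(-c2cc(-c3cccc(F)c3)cc(-c3ccc(O)cc3)n2)cc1` reaches only the limit of the assay, reported as > 50000 nM. Compound 3 `Oc1ccc(-c2cc(-c3cccc(C(F)(F)F)c3)cc(-c3cccc(O)c3)n2)cc1` gives 9540 nM. Of the two numbers recorded, compound 3 stands highest, and its nearest neighbour is compound 1, whose number lies within the usual scatter of it. Among the measured compounds shown here, the only step measured between neighbours, an at least 6.1-fold higher number from compound 1 to compound 2 (0.78 log units; beyond the scatter), concerns the fluorophenyl group, and it runs up to the limit of > 50000 nM in this assay, at which 1 of the 3 values shown sits, so its true size is not known.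

Compound 4 `Oc1ccc(-c2cc(-c3cccc(C(F)(F)F)c3)cc(-c3ccc(O)cc3)n2)cc1` differs from compound 3 by 4-hydroxyphenyl in place of 3-hydroxyphenyl on an aromatic carbon. For the measured compounds named here, no measured step exchanges a 3-hydroxyphenyl for a 4-hydroxyphenyl, so the step from compound 1 to compound 2 offers no direct guide here. In the absence of such a comparison, the change is expected to leave this assay within the scatter. Compound 4 is therefore expected to give about 9000 nM, with a range from 3000 nM to 30000 nM. The expected step of a 1.1-fold lower number from compound 3 to compound 4 (0.03 log units; within the scatter) is accordingly small.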

Compound 4, half-maximal inhibitory concentration: > 50000 nM
Compound 4 ended at the assay's limit; the forecaster's own chance of this, stated with the estimate: 15%; middle value at least 5.5-fold (0.74 log units) away from the limit.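

On the aromatic carbon next to the ring nitrogen, 4-hydroxyphenyl in place of 3-hydroxyphenyl gives an at least 5.2-fold higher number from compound 3 to compound 4 (0.71 log units; beyond the scatter), so in this assay this place responds to a change that leaves the atoms of the group the same, whereas the earlier step concerned only the fluorophenyl group. 3-(Trifluoromethyl)phenyl in place of 2-fluorophenyl gives an at least 6.1-fold higher number from compound 1 to compound 4 (0.78 log units; beyond the scatter), while the step from compound 2 to compound 4 cannot be read. The true size of the readable steps is also unknown: the limit of > 50000 nM in this assay, at which 2 of the 4 values shown sit.

Compound 1 carries 4-hydroxyphenyl at this place and still gives 8180 nM, so the effect of that group depends on the rest of the molecule. As far as these compounds go, whether 2-hydroxyphenyl or an aminophenyl group at this place would be tolerated remains open, as does whether 3-hydroxyphenyl would have the same effect alongside a fluorophenyl group.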